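The compounds below may be only part of what the source reports. "The series", "measured", "known", "first", "only" and "open" are said of these compounds alone.

Measured compounds:
Compound 1 `CCCN(CCC(F)(F)F)Cc1c(C(F)(F)F)nc2n(-c3c(C)cc(C)cc3C)c(Cl)cn12` gives 12 nM in an assay on cells for displacement of a labelled ligand from corticotropin-releasing factor receptor 1 (Homo sapiens), with a stated time of 100 min; on this read-out lower numbers stand for stronger inhibition and higher numbers for weaker inhibition.
Compound 2 `C=C(C)CN(CC)Cc1c(C(F)(F)F)nc2n(-c3c(C)cc(C)cc3C)c(Cl)cn12` gives 67 nM in this assay.
Compound 3 `Cc1cc(C)c(-n2c(Cl)cn3c(CN(CCC(F)(F)F)Cc4ccc(F)cc4)c(C(F)(F)F)nc23)c(C)c1` gives 34 nM in this assay.

All three share the same core and differ only in the two groups carried on the amine nitrogen of the side chain. Compound 1 has the lowest number of the three, so it is the strongest binder shown; the step of a 2.8-fold higher number from compound 1 to compound 3 (0.45 log units; beyond the scatter) is the nearer one, and the step of a 5.6-fold higher number from compound 1 to compound 2 (0.75 log units; beyond the scatter) is the further one.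

Compound 4 `CCCN(Cc1ccc([N+](=O)[O-])cc1)Cc1c(C(F)(F)F)nc2n(-c3c(C)cc(C)cc3C)c(Cl)cn12` has not been measured yet. It differs from compound 1 in one place: 4-nitrophenyl in place of 2,2,2-trifluoroethyl on a saturated chain carbon bound to an amine nitrogen. This resembles the step from compound 1 to compound 3, where an aromatic ring was likewise introduced on a saturated chain carbon bound to the amine nitrogen, and that step weakened binding modestly, as shown by a 2.8-fold higher number from compound 1 to compound 3 (0.45 log units; beyond the scatter). For the measured compounds named here, no measured pair tests a nitro-bearing ring, so the expectation rests on that single analogy. A modest loss is therefore expected, with the step of a 2.9-fold higher number from compound 1 to compound 4 (0.46 log units; beyond the scatter). Compound 4 is estimated at 35 nM in this assay, with a likely range from 12 nM to 110 nM.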

Compound 4, inhibition constant: 150 nM
Estimate against measurement, compound 4: 4.3-fold (0.63 log units) below; measured number outside the range, above it.
By their numbers in this assay, from the lowest: compound 1; then compounds 3 and 2 (each within the scatter of the next); then compound 4.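

this assay shows a 13-fold higher number from compound 1 to compound 4 (1.10 log units; beyond the scatter) and this is the only large step from compound 1 among those shown, so bringing an aromatic ring onto this side chain does not always cost only a modest amount. The other step that adds a ring gives a 2.8-fold higher number from compound 1 to compound 3 (0.45 log units; beyond the scatter) but differs in two ways: it keeps the 3,3,3-trifluoropropyl group and places 4-fluorophenyl where ethyl stood, whereas the new step replaces that group with 4-nitrobenzyl. Nothing measured here accounts for the larger loss.

The compounds shown cannot separate the contribution of the nitro group from that of the ring itself or of losing the 3,3,3-trifluoropropyl group. A plain benzyl group on the same propyl-bearing amine would begin to separate these contributions, and a 4-fluorobenzyl group there would test the ring substituent directly.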